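Notes on the step from nitro to fluoro

The compounds below may be only part of what the source reports. "The series", "measured", "known", "first", "only" and "open" are said of these compounds alone.

Measured in a functional assay on Jurkat cells (Homo sapiens); a lower number here means a stronger inhibitor, a higher number a weaker inhibitor:
- compound 1 `CC(C)[C@H](NC(=O)COc1cccc2ccccc12)C(=O)N[C@@H](CC(=O)O)C(=O)COc1ccc(-c2ccccc2)cc1`: 87900 nM
- compound 2 `CC(C)[C@H](NC(=O)COc1cccc2ccccc12)C(=O)N[C@@H](CC(=O)O)C(=O)COc1ccccc1[N+](=O)[O-]`: > 100000 nM (a limit of the assay, not a number)

Compound 2 stands only at a limit, > 100000 nM. Compound 3 `CC(C)[C@H](NC(=O)COc1cccc2ccccc12)C(=O)N[C@@H](CC(=O)O)C(=O)COc1ccccc1F` carries fluoro in place of nitro on an aromatic carbon, ortho to a large group: fluoro in place of nitro on an aromatic carbon. Among the compounds with values here, the sole measured step, an at least 1.1-fold higher number from compound 1 to compound 2 (0.05 log units; that floor lies within the scatter), changes the same aryl group, and its floor lies within the scatter. Within the data shown here, no measured step exchanges nitro for fluoro, so no step beyond the scatter is expected in this assay. The expected step is an at least 1.1-fold lower number from compound 2 to compound 3 (0.04 log units; that floor lies within the scatter). Compound 3 is estimated at 90000 nM, with an expected range of 40000 nM to 150000 nM.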

Compound 3, half-maximal inhibitory concentration: > 100000 nM
Compound 3 was reported as a limit; the forecaster's own chance of this, stated with the estimate: 55%; middle value at least 1.1-fold (0.04 log units) from the limit.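

Compound 3 stands at a limit of the assay in this assay, > 100000 nM, so fluoro on this aromatic carbon, like nitro, yields no number. Within the data shown here, the step between the two limits cannot be read, and the only readable comparison at this aryl group is an at least 1.1-fold higher number from compound 1 to compound 3 (0.05 log units; that floor lies within the scatter). What this small set can show is now bounded by the assay's ceiling: the limit of > 100000 nM in this assay, at which 2 of the 3 values shown sit.

On these data alone, it remains open whether any group at this place, such as an amine or a carboxylic acid, brings a value under the limit. As far as these compounds go, how far compound 2 and compound 3 lie beyond it also remains open.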